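Swapping the Amide Aryl Ring: From Pyridine Back to Benzene

The compounds below may be only part of what the source reports. "The series", "measured", "known", "first", "only" and "open" are said of these compounds alone.

Measured so far:
compound 1 `O=C(Nc1ccc(S(=O)(=O)Nc2ccccc2)cc1)c1ccc(Cl)cc1Br`, 123%
compound 2 `O=C(Nc1ccc(S(=O)(=O)Nc2ccccc2)cc1)c1ccc(Cl)nc1F`, 78%

In a functional assay on HEK293 cells for agonist activity at probable G-protein coupled receptor 27 (Homo sapiens), read by a luciferase reporter and beta-arrestin recruitment, with a stated time of 10 min (on this read-out higher numbers stand for larger maximal responses and lower numbers for smaller maximal responses), compound 1 gives 123%, and compound 2 gives 78%, the lowest of the two numbers. Within the data shown here, the only measured step here is a number 45 percentage points lower from compound 1 to compound 2 (beyond the scatter), so the one change in this pair cost a lot of maximal response.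

Compound 3 `Cc1cc(Br)ccc1C(=O)Nc1ccc(S(=O)(=O)Nc2ccccc2)cc1` is the next compound to be tested. It differs from compound 2 in one place: 4-bromo-2-methylphenyl in place of 6-chloro-2-fluoropyridin-3-yl on a carbonyl carbon. Like compound 1, compound 3 therefore carries a six-membered aromatic ring of carbon only on the carbonyl carbon, rather than a ring with one hetero atom.

The step that bears on this change is a number 45 percentage points lower from compound 1 to compound 2 (beyond the scatter), which was large and went downward when the carbon-only ring was replaced by the ring with one hetero atom. Reversing that kind of change suggests the maximal response will recover, so an upward step is expected, estimated as a number 32 percentage points higher from compound 2 to compound 3 (beyond the scatter). Compound 3 is therefore estimated at 110%, with a range from 85% to 135%.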

Compound 3, largest response reached (Emax), in percent of the reference or control that the assay uses: 103%
Compound 3: the middle estimate sits 7 percentage points above what was measured; low and high end bracket the measured number.
By their numbers in this assay, from the lowest: compound 2; then compound 3; then compound 1.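

In this assay, the change to 4-bromo-2-methylphenyl on the carbonyl carbon gives a number 25 percentage points higher from compound 2 to compound 3 (beyond the scatter), so a second ring of carbon only also stands above the ring with one hetero atom, and the higher response is not confined to the 2-bromo-4-chlorophenyl of compound 1. The two carbon-only rings are still not interchangeable: replacing 2-bromo-4-chlorophenyl with 4-bromo-2-methylphenyl gives a number 20 percentage points lower from compound 1 to compound 3 (beyond the scatter), so the groups carried by the ring matter as well as the ring itself. Nothing available here explains either difference.

Each of these swaps changes several atoms at once, so the three compounds cannot separate the effect of the ring nitrogen from that of the fluorine, chlorine, bromine or methyl groups. On these data alone, it also remains open how the maximal response would move with a methoxy or trifluoromethyl group on the phenyl ring, or with a pyridine ring carrying the same bromine and methyl groups as compound 3.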